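Two Weak Antiproliferative Amides and an Untested Hybrid

This account rests on a few compounds, and the source may have more. Where it says the series, first, only, none or still open, it means among the compounds named here.

Compound 1 `NC(=O)c1c(NC(=O)c2ccc(C(F)(F)F)cc2)sc2c1CCN(Cc1c(Cl)cccc1Cl)C2` in a functional assay on MKN-74 cells (Homo sapiens) for antiproliferative activity, with a stated time of 24 h (on this read-out lower numbers stand for stronger inhibition and higher numbers for weaker inhibition), gives 8530 nM.
Compound 2 `CSc1ccccc1C(=O)Nc1sc2c(c1C(N)=O)CCN(C(=S)Nc1ccccc1Cl)C2` in this assay gives 6550 nM.

Compound 2 stands at the lowest of the two numbers, but its nearest neighbour, compound 1, sits within the usual scatter of it, so the two values show no order between them. Compound 3 `NC(=O)c1c(NC(=O)c2ccc(C(F)(F)F)cc2)sc2c1CCN(C(=S)Nc1ccccc1Cl)C2` differs from compound 2 in one place: 4-(trifluoromethyl)phenyl in place of 2-(methylsulfanyl)phenyl on a carbonyl carbon. Going by the values given here, no pair of measured compounds isolates this change, so no measured step can be carried over. Among the compounds with values here, the only guide is that compound 1 already carries the entering 4-(trifluoromethyl)phenyl group and still returns a number close to that of compound 2. On that basis the step from compound 2 to compound 3 is expected to be small, a 1.1-fold higher number from compound 2 to compound 3 (0.03 log units; within the scatter), with no direction beyond the scatter. Compound 3 is therefore estimated at 7000 nM in this assay, with a range from 2500 nM to 20000 nM.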

Compound 3, half-maximal inhibitory concentration: 16400 nM
Beside the measured number, compound 3's estimate is 2.3-fold (0.37 log units) below it; low and high end bracket the measured number.
By their numbers in this assay, from the lowest: compounds 2, 1 and 3 (each within the scatter of the next, the first and the last beyond it).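

On a carbonyl carbon whose other neighbour is the amide-type nitrogen, this assay now gives a first isolated reading: 4-(trifluoromethyl)phenyl in place of 2-(methylsulfanyl)phenyl goes with a 2.5-fold higher number from compound 2 to compound 3 (0.40 log units; beyond the scatter), a modest weakening of inhibition. The change on the amine nitrogen in a ring, which links the other pair, gives a 1.9-fold higher number from compound 1 to compound 3 (0.28 log units; within the scatter), so this exchange of groups shows no separation on this read-out. Nothing shown here bears on what lies behind the step at the carbonyl carbon.

The compounds shown do not tell whether that step follows the loss of 2-(methylsulfanyl)phenyl or the arrival of 4-(trifluoromethyl)phenyl, a question that a plain phenyl or a pyridine ring on the same carbonyl carbon would address. Going by these compounds, it also remains open whether the step keeps its size with another group, such as an acetyl group, on the amine nitrogen in a ring.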